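Swapping the far aryl ring of an unsymmetrical curcuminoid

This account rests on a few compounds, and the source may have more. Where it says the series, first, only, none or still open, it means among the compounds named here.

Compound 1, `CN(C)Cc1cc(/C=C/C(=O)/C=C(O)/C=C/c2ccc(O)cc2)ccc1O`, gives 7600 nM in a functional assay, with a stated time of 19 h; on this read-out lower numbers stand for stronger inhibition and higher numbers for weaker inhibition.
Compound 2, `COc1ccc(/C=C/C(O)=C/C(=O)/C=C/c2ccc(O)c(CN(C)C)c2)cc1OC`, gives 27400 nM in this assay.

Among the compounds with values here, of the two numbers measured so far, compound 2 stands highest; its nearest neighbour is compound 1, and the step of a 3.6-fold higher number from compound 1 to compound 2 (0.56 log units; beyond the scatter) lies beyond the scatter. That step is the only one measured, and it bears on the next change only in part, since it altered the same ring from 4-hydroxyphenyl to 3,4-dimethoxyphenyl.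

Compound 3, `Cc1ccc(/C=C/C(O)=C/C(=O)/C=C/c2ccc(O)c(CN(C)C)c2)cc1`, has not yet been measured in this assay. It differs from compound 2 as follows: 4-methylphenyl in place of 3,4-dimethoxyphenyl on a double-bonded chain carbon bound to a double-bonded chain carbon. Within the data shown here, no measured pair shows what removing both methoxy groups and placing a methyl on that ring does, so the direction is open. Given that compound 1, whose ring carries a hydroxyl, gives 7600 nM, and that compound 2 gives 27400 nM, compound 3 is expected to fall between or near these, and the estimate is a step of a 1.8-fold lower number from compound 2 to compound 3 (0.26 log units; within the scatter). The estimate for compound 3 is 15000 nM, within 5000 nM to 50000 nM.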

Compound 3, half-maximal inhibitory concentration: 22000 nM
The estimate for compound 3 lay 1.5-fold (0.17 log units) below the measured number; the range from low to high includes it.
By their numbers in this assay, from the lowest: compound 1; then compounds 3 and 2 (each within the scatter of the next).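

In this assay, 4-methylphenyl in place of 3,4-dimethoxyphenyl on a double-bonded chain carbon bound to a double-bonded chain carbon gives a 1.2-fold lower number from compound 2 to compound 3 (0.10 log units; within the scatter), so this read-out does not separate these two rings, although the entering group carries no oxygen. Methyl in place of hydroxy on an aromatic carbon gives a 2.9-fold higher number from compound 1 to compound 3 (0.46 log units; beyond the scatter), and with a 3.6-fold higher number from compound 1 to compound 2 (0.56 log units; beyond the scatter) this places compound 1, with its 4-hydroxyphenyl ring, lowest of the three, beyond the scatter from both of the others. Nothing among the data shown accounts for these numbers.

Within the data shown here, with only one hydroxy-bearing ring among the three compounds, it remains open whether the lower number of compound 1 belongs to the hydroxy group itself or would also appear with another group on that aromatic carbon, such as an amine, a carboxylic acid or a fluorine atom. The three compounds also share the dimethylaminomethyl-bearing ring, so they leave open whether the same order of rings would hold if that side carried a longer chain or a different amine.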